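Lengthening the chain of compound 2

This account rests on a few compounds, and the source may have more. Where it says the series, first, only, none or still open, it means among the compounds named here.

Within the data shown here, in a functional assay on CCRF-CEM cells (Homo sapiens) for antiproliferative activity, read by MTT assay (a higher number here means a weaker inhibitor, a lower number a stronger inhibitor), compound 2 (`CC/C(=N\Nc1nc2ccccc2o1)c1ccccn1`) gives 4 nM as the lowest of the three numbers so far. Compound 3 (`C/C(=N\Nc1nc2ccccc2o1)c1cc(C)ncn1`) stands at 230 nM and compound 1 (`C/C(=N\Nc1nc2ccccc2o1)c1cnc(C)cn1`) at 620 nM with both beyond the scatter from compound 2. Compound 4 (`CCC/C(=N\Nc1nc2ccccc2o1)c1ccccn1`) turns the ethyl chain into propyl: methyl in place of hydrogen on a saturated chain carbon, two bonds along the chain from a carbon with a double bond to nitrogen on a saturated chain carbon, two bonds along the chain from a carbon with a double bond to nitrogen. Among the measured compounds shown here, no measured pair shows this change, so the expectation is tentative. In this assay a small loss, probably within the scatter, is expected, the estimated 1.8-fold higher number from compound 2 to compound 4 (0.24 log units; within the scatter) being no large move. The estimated value for compound 4 is 7 nM (expected range 2 nM to 30 nM) .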

Compound 4, half-maximal inhibitory concentration: 6 nM
Compound 4: the middle estimate sits 1.2-fold (0.07 log units) above what was measured; the range from low to high includes it.
By their numbers in this assay, from the lowest: compounds 2 and 4 (each within the scatter of the next); then compound 3; then compound 1.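

In this assay, ethyl to propyl, with methyl in place of hydrogen on a saturated chain carbon, two bonds along the chain from a carbon with a double bond to nitrogen, gives a 1.5-fold higher number from compound 2 to compound 4 (0.18 log units; within the scatter). This first single-place step in the series shows that this position accepts the added methyl without a difference that stands clear of the scatter. No measurement here bears on the reason for this result.

On these data alone, whether a butyl chain, a branched isopropyl chain, or a chain ending in an amine or a carboxylic acid would also stay within the scatter remains open.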